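The source may report more compounds than this note shows. Statements on the series, on what has been measured and on what is new or still open speak of the compounds shown alone.

Of the compounds shown here, three that share one core have been tested in a functional assay on CHO-K1 cells for antagonist activity at adenosine receptor A1 (Homo sapiens), read by a beta-galactosidase reporter and cAMP accumulation, with stated times of 15 min and 6 h; a higher number here means a weaker inhibitor, a lower number a stronger inhibitor. Compound 1 `Nc1nc(-c2cnco2)nc2sc(Cc3ccccc3)cc12` gives 106 nM. Compound 2 `Nc1nc(-c2ccccc2)nc2sc(Cc3ccccc3)cc12` gives 151 nM. Compound 3 `N#Cc1cccc(-c2nc(N)c3cc(Cc4ccccc4)sc3n2)c1` gives 222 nM, the highest of the three numbers. Its nearest neighbour is compound 2, because a 1.5-fold higher number from compound 2 to compound 3 (0.17 log units; within the scatter). The gap to compound 1 is larger, since a 2.1-fold higher number from compound 1 to compound 3 (0.32 log units; beyond the scatter). Between the first two compounds, a 1.4-fold higher number from compound 1 to compound 2 (0.15 log units; within the scatter).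

Compound 4 `Nc1nc(-c2cccnc2)nc2sc(Cc3ccccc3)cc12` has not yet been measured. It differs from compound 3 in one place: pyridin-3-yl in place of 3-cyanophenyl on an aromatic carbon. Among the compounds with values here, the steps that bear on this are the ones already seen at the same ring position, where swapping the group gave changes of modest size or none beyond the scatter. The new group carries one hydrogen-bond acceptor, as the departing one does, and resembles the phenyl of compound 2 in size. Little movement in this assay is therefore expected, with the number for compound 4 most likely sitting near those of compound 2 and compound 3. The estimate for compound 4 is 140 nM, with an expected range from 60 nM to 330 nM. This estimate means a 1.6-fold lower number from compound 3 to compound 4 (0.20 log units; within the scatter), expected to stay within the scatter.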

Compound 4, inhibition constant: 1420 nM
Compound 4: the middle estimate sits 10-fold (1.01 log units) below what was measured; measured number outside the range, above it.
By their numbers in this assay, from the lowest: compounds 1, 2 and 3 (each within the scatter of the next, the first and the last beyond it); then compound 4.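

At this carbon between two ring nitrogen atoms, the earlier groups differed only modestly, yet pyridin-3-yl stands well apart in this assay: replacing 3-cyanophenyl gives a 6.4-fold higher number from compound 3 to compound 4 (0.81 log units; beyond the scatter) and replacing phenyl gives a 9.4-fold higher number from compound 2 to compound 4 (0.97 log units; beyond the scatter) here. Against the 1,3-oxazol-5-yl the change is large, with a 13-fold higher number from compound 1 to compound 4 (1.13 log units; beyond the scatter) as the result, so putting a ring nitrogen into the phenyl moved the number further than any step among the earlier compounds, and an equal count of hydrogen-bond acceptors in 3-cyanophenyl and pyridin-3-yl did not keep their numbers together. Nothing available here accounts for this gap.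

Still open, from the compounds shown here alone, is whether the weakening belongs to pyridin-3-yl alone or extends to pyridin-2-yl and pyridin-4-yl. Also open, going by these compounds, is how a pyrimidin-5-yl or a 3-methoxyphenyl would behave at this carbon.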